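A few compounds are considered here, and "the series" means these few. Any claim that something is new, unique, unknown or untested is made for them only; others in the source may bear on it.

Measured compounds in this series:
compound 1 `CC(C)CCn1nc(-c2cccs2)c(O)c(C2=NS(=O)(=O)c3cc(CS(C)(=O)=O)ccc3N2)c1=O`, 0.467 h
compound 2 `CS(=O)(=O)Nc1ccc2c(c1)S(=O)(=O)N=C(c1c(O)c(-c3ccc(Cl)s3)nn(CCC3CC3)c1=O)N2`, > 1 h
compound 3 `COC(C)(C)CCn1nc(-c2cccs2)c(O)c(C2=NS(=O)(=O)c3cc(NS(C)(=O)=O)ccc3N2)c1=O`, > 1 h

In an in vitro ADME assay on microsomes from liver (Homo sapiens) for metabolic stability, tested at 5 uM (on this read-out higher numbers stand for a longer-lived compound and lower numbers for a shorter-lived compound), compound 1 gives 0.467 h. For compound 2 the result is > 1 h, which is a limit of the assay rather than a number. Compound 3 likewise stands at > 1 h, again a limit and not a number. So compound 3 sits at the limit of > 1 h in this assay, at which 2 of the 3 values shown sit, together with compound 2, while compound 1 is the only member with a resolved number and it lies below that limit. Where compound 3 truly stands above the limit cannot be read from these data.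

Compound 4 `CS(=O)(=O)Nc1ccc2c(c1)S(=O)(=O)N=C(c1c(O)c(-c3cccs3)nn(CCC3CCCCC3)c1=O)N2` is not yet measured. It differs from compound 3 by cyclohexyl in place of 1-methoxy-1-methylethyl on a saturated chain carbon, two bonds along the chain from an aromatic nitrogen. Going by the values given here, no step between two measured compounds isolates this change, and the nearest neighbours differ in more than one place, so the size of the effect is open. A downward step of moderate size in this assay is expected, an at least 1.4-fold lower number from compound 3 to compound 4 (0.15 log units; that floor lies within the scatter), because compound 1 shows 0.467 h with a chain lacking the oxygen-bearing group. Compound 4 is estimated at 0.7 h, with a range from 0.3 h to 1.6 h.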

Compound 4, half-life: > 1 h
Compound 4: no number, only a limit; the forecaster's own chance of this, stated with the estimate: 30%; middle value at least 1.4-fold (0.15 log units) away from the limit.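

Going by these compounds alone, compound 3 and compound 4 both stand at a limit in this assay rather than at a number, so no step between them can be read. The compounds shown leave open whether cyclohexyl in place of 1-methoxy-1-methylethyl changes the half-life at all.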